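Series notes: from compound 1 to compound 4

The compounds below may be only part of what the source reports. "The series", "measured", "known", "first", "only" and "open" are said of these compounds alone.

Compound 1 `Cc1cc(-c2cccc(F)c2)c2ncc(CSCCc3ccccc3)n2c1` — in an ADME assay on HEL cells (Homo sapiens) for cytotoxicity, with a stated time of 3 days (a lower number here means that less compound is tolerated, a higher number that more compound is tolerated), compound 1 gives 35 ug/mL.
Compound 2 `Cc1cc(-c2ccccc2)cn2c(CSCCc3ccccc3)cnc12` — in this assay compound 2 gives 31 ug/mL.
Compound 3 `Cc1cc(-c2ccsc2)cn2c(CSCCc3ccccc3)cnc12` — in this assay compound 3 gives > 50 ug/mL, which is a limit of the assay and not a number.

Compound 1 stands at the upper of the two numbers shown, with compound 2 within the scatter of it. Compound 4 `Cc1cc(-c2cccs2)c2ncc(CSCCc3ccccc3)n2c1` is not yet measured. It differs from compound 1 by thiophen-2-yl in place of 3-fluorophenyl on an aromatic carbon. Among the measured compounds shown here, the only measured step that bears on this change is an at least 1.6-fold higher number from compound 2 to compound 3 (0.20 log units; that floor lies within the scatter), which rests on the limit of > 50 ug/mL in this assay, at which 1 of the 3 values shown sits, and has a floor within the scatter. No step beyond the scatter is therefore expected for compound 4, though the value may again reach the limit. The estimate for compound 4 in this assay is 45 ug/mL, with a range from 25 ug/mL to 80 ug/mL. This estimate means an expected step of a 1.3-fold higher number from compound 1 to compound 4 (0.11 log units; within the scatter).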

Compound 4, half-maximal cytotoxic concentration: > 50 ug/mL
Compound 4: a limit, no number (the forecaster's own chance of this, stated with the estimate: 40%); middle value at least 1.1-fold (0.04 log units) from the limit.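

In this assay, thiophen-2-yl in place of 3-fluorophenyl on this aromatic carbon, ortho to a fused ring, gives an at least 1.4-fold higher number from compound 1 to compound 4 (0.15 log units; that floor lies within the scatter). Among the compounds shown here, this is the first reading at this position of a five-membered aromatic ring with a sulfur atom, and it shows no fall in the tolerated concentration. The true size of the step cannot be read, as compound 4 gives a limit and not a number: the limit of > 50 ug/mL in this assay, at which 2 of the 4 values shown sit.

From the compounds shown here alone, it remains open whether an amine or a carboxylic acid on this carbon would give a number below the limit. Going by these compounds, whether thiophen-3-yl at this position would behave like thiophen-2-yl also remains open.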